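Extending the Chain Toward a Selenourea Analogue

The compounds below may be only part of what the source reports. "The series", "measured", "known", "first", "only" and "open" are said of these compounds alone.

Measured compounds:
compound 1 `CCOC(=[Se])Nc1ccc2c(C)cc(=O)oc2c1` gives > 100000 nM
compound 2 `CCCOC(=[Se])Nc1ccc2c(C)cc(=O)oc2c1` gives 37000 nM

Compound 1 carries an ethyl group on the oxygen of the selenocarbamate, and in a functional assay on A549 cells (Homo sapiens) for inhibition, read by sulforhodamine B assay, with a stated time of 48 h (a lower number here means a stronger inhibitor of growth, a higher number a weaker inhibitor of growth), compound 1 reaches only a limit of the assay at > 100000 nM. Among the measured compounds shown here, compound 2 differs by one carbon on that chain, and in this assay compound 2 gives 37000 nM, the only actual number among the two values shown. The step of an at least 2.7-fold lower number from compound 1 to compound 2 (0.43 log units; beyond the scatter) shows that lengthening the chain by one carbon moved the number downward, and the limit of > 100000 nM in this assay, at which 1 of the 2 values shown sits, means its true size is not known exactly.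

Compound 3 `CCCCNC(=[Se])Nc1ccc2c(C)cc(=O)oc2c1` has not yet been measured. It differs from compound 2 by butylamino in place of propoxy on a saturated chain carbon bound to a nitrogen on an aromatic ring. The chain grows by one carbon again, and the oxygen linking it becomes a nitrogen bearing a hydrogen. For the measured compounds named here, only the step from compound 1 to compound 2 bears on this, and it concerns the chain length, not the oxygen-to-nitrogen exchange. A modest downward step is expected, a 1.9-fold lower number from compound 2 to compound 3 (0.27 log units; within the scatter) in this assay. Compound 3 is estimated to give 20000 nM, in the range 5000 nM to 80000 nM.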

Compound 3, concentration for 50% growth inhibition: 3000 nM
Beside the measured number, compound 3's estimate is 6.7-fold (0.82 log units) above it; the measured number lies below the stated range.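

In this assay, replacing propoxy with butylamino gives a 12-fold lower number from compound 2 to compound 3 (1.09 log units; beyond the scatter), a large step, while the earlier change within the oxygen-linked chains gave an at least 2.7-fold lower number from compound 1 to compound 2 (0.43 log units; beyond the scatter). This position therefore responds far more strongly to this exchange than the first step alone could suggest, and compound 3 is the only compound shown with a nitrogen bearing a hydrogen in that chain, which brings a hydrogen-bond donor count of 1 where propoxy has 0. Over both changes, the move from ethoxy to butylamino gives an at least 33-fold lower number from compound 1 to compound 3 (1.52 log units; beyond the scatter), and the true size of this step stays open because compound 1 sits at a limit of the assay: the limit of > 100000 nM in this assay, at which 1 of the 3 values shown sits.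

The step to compound 3 changes two things at once, the chain length and the atom linking the chain, so the compounds shown cannot tell how much of the gain belongs to each. A propylamino group would keep the chain of compound 2 while exchanging the oxygen for nitrogen, a butoxy group would keep the chain of compound 3 with the oxygen, and a longer chain such as pentylamino would test whether further lengthening still lowers the number.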